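A few compounds are considered here, and "the series" means these few. Any claim that something is new, unique, unknown or untested is made for them only; others in the source may bear on it.

Compound 1 `Cc1ccccc1-c1nn(-c2ccc(F)cc2F)cc1CNCCCCO`: > 20000 nM
Compound 2 `COc1ccc(-n2cc(CNCCN3CCN(C)CC3)c(-c3ccccc3C)n2)cc1`: > 20000 nM

Both results come from an ADME assay on Huh-7 cells (Homo sapiens) for cytotoxicity; a lower number here means that less compound is tolerated, a higher number that more compound is tolerated. For compound 1 the result is a limit of the assay rather than a number, namely > 20000 nM. For compound 2 the result is likewise only a limit, > 20000 nM. Within the data shown here, compound 2 therefore stands at the limit of > 20000 nM in this assay, at which 2 of the 2 values shown sit, and no step between measured compounds is available to show how a structural change moves the readout.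

Compound 3 `Cc1ccccc1-c1nn(-c2cccc(C(F)(F)F)c2)cc1CNCCN1CCN(C)CC1` differs from compound 2 in a single place: 3-(trifluoromethyl)phenyl in place of 4-methoxyphenyl on an aromatic nitrogen. With both measured results resting at the limit of > 20000 nM in this assay, at which 2 of the 2 values shown sit, the expectation for compound 3 is that it too remains at that limit, with no step beyond the usual scatter. For compound 3 the expected result in this assay is 25000 nM, with a range of 8000 nM to 80000 nM. That expected value corresponds to a step that the limit leaves unreadable from compound 2 to compound 3, within the scatter.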

Compound 3, half-maximal cytotoxic concentration: 18000 nM
For compound 3 the middle estimate is 1.4-fold (0.14 log units) above the measured one; the measured number falls inside the stated range.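

With 3-(trifluoromethyl)phenyl in place of 4-methoxyphenyl on the aromatic nitrogen, this assay shows an at least 1.1-fold lower number from compound 2 to compound 3 (0.04 log units; that floor lies within the scatter). Among these compounds, compound 3 is the first compound here to give an actual number, 18000 nM, so this series can yield a reading within the range of the assay. As far as these compounds go, the value for compound 2 is only a limit, so the true size of the step stays unknown. Most of the values shown still rest at that limit: the limit of > 20000 nM in this assay, at which 2 of the 3 values shown sit.

The compounds shown leave open whether the reading for compound 3 belongs to the trifluoromethyl group itself or to where it sits on the phenyl ring. They also leave open how an amine or a carboxylic acid on that phenyl ring would read in this assay.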